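A few compounds are considered here, and "the series" means these few. Any claim that something is new, unique, unknown or untested is made for them only; others in the source may bear on it.

Three amides built on one shared core have been tested in an in vitro functional assay on HEK293-A cells for antagonist activity at metabotropic glutamate receptor 5 (Rattus norvegicus), read by calcium flux; a lower number here means a stronger inhibitor, a higher number a weaker inhibitor. Compound 1 `N#Cc1cc(F)cc(C(=O)Nc2cccnc2)c1` gives > 30000 nM, which is a limit of the assay rather than a measured number. Compound 2 `N#Cc1cc(F)cc(C(=O)Nc2ccccc2F)c1` likewise gives only the limit > 30000 nM. Compound 3 `N#Cc1cc(F)cc(C(=O)Nc2ccccc2Cl)c1` also stops at the limit > 30000 nM. The step from compound 2 to compound 3, a step that the two limits leave unreadable from compound 2 to compound 3, cannot be read because of the limit of > 30000 nM in this assay, at which 3 of the 3 values shown sit. Compound 4 `Cc1ccccc1NC(=O)c1cc(F)cc(C#N)c1` differs from compound 3 by methyl in place of chloro on an aromatic carbon. For the measured compounds named here, no measured step has a readable size, so the limit of > 30000 nM in this assay, at which 3 of the 3 values shown sit, is the only evidence that bears on this change. Compound 4 is therefore expected to stay at the limit as well, a step that the limit leaves unreadable from compound 3 to compound 4 in this assay. The estimate for compound 4 is 45000 nM, within 12000 nM to 170000 nM.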

Compound 4, half-maximal inhibitory concentration: > 30000 nM
Compound 4: a limit, no number; the forecaster's own chance of this, stated with the estimate: 85%; the middle value does not contradict the limit.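

Compound 4 also stops at a limit of the assay, so its steps from compound 2 and compound 3 cannot be read: the limit of > 30000 nM in this assay, at which 4 of the 4 values shown sit.

The compounds shown leave open whether any amide on this shared core gives a readable number, and how these groups compare.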